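The compounds below may be only part of what the source reports. "The series", "measured", "known", "first", "only" and "open" are said of these compounds alone.

Measured compounds in an ADME assay on HeLa cells (Homo sapiens) for cytotoxicity, read by MTT assay; on this read-out higher numbers stand for weaker inhibition and lower numbers for stronger inhibition:

compound 1 `COc1ccc(C[C@H]2COC(=O)[C@@H]2Cc2ccc(OCC(=O)Nc3ccc(C)cc3)c(OC)c2)cc1OC`: 228000 nM
compound 2 `COc1ccc(C[C@H]2COC(=O)[C@@H]2Cc2ccc(OC(=O)CCC(=O)N3CCCC3)c(OC)c2)cc1OC`: 201000 nM
compound 3 `CCN(CC)C(=O)CCC(=O)Oc1ccc(C[C@H]2C(=O)OC[C@@H]2Cc2ccc(OC)c(OC)c2)cc1OC`: 213000 nM

Compound 1 carries the highest of the three numbers, but neither gap is meaningful: a 1.1-fold lower number from compound 1 to compound 2 (0.05 log units; within the scatter) and a 1.1-fold lower number from compound 1 to compound 3 (0.03 log units; within the scatter), and between the two amides a 1.1-fold higher number from compound 2 to compound 3 (0.03 log units; within the scatter). All three values therefore describe weak cytotoxicity at essentially one level.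

Compound 4 `COc1ccc(C[C@H]2COC(=O)[C@@H]2Cc2ccc(OCc3cn(-c4ccc(F)cc4)nn3)c(OC)c2)cc1OC` is the next member. Relative to compound 1 the change is 1-(4-fluorophenyl)-1H-1,2,3-triazol-4-yl in place of (4-methylphenyl)carbamoyl on a saturated chain carbon bound to an oxygen on an aromatic ring. The group that leaves carries one hydrogen-bond donor and one acceptor; the group that enters carries no donor and three acceptors, plus a fluorine, and is larger by two heavy atoms.

Going by the values given here, the steps that bear on this change are the two from compound 1, which also swap the whole group hanging on the oxygen on the aromatic ring, in one case for a ring-bearing amide and in one case for an open-chain amide; both stayed within the scatter. The shared core with its two dimethoxyphenyl arms thus seems to set the level in this assay, while the appended group has so far hardly moved it. Compound 4 is accordingly expected to stay close to compound 1, with a 1.1-fold lower number from compound 1 to compound 4 (0.03 log units; within the scatter) as the estimated step. The estimate for compound 4 is 215000 nM, expected between 110000 nM and 420000 nM.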

Compound 4, half-maximal inhibitory concentration: >= 600000 nM
Compound 4: no number, only a limit; the forecaster's own chance of this, stated with the estimate: 20%; middle value at least 2.7-fold (0.44 log units) away from the limit.
By their numbers in this assay, from the lowest: compounds 2, 3 and 1 (each within the scatter of the next). At a limit, above all of these: compound 4.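

In this assay compound 4 gives >= 600000 nM, which is a limit of the assay and not a number: the limit of >= 600000 nM in this assay, at which 1 of the 4 values shown sits. Even so, this position on a saturated chain carbon bound to an oxygen on an aromatic ring is not silent: an at least 2.6-fold higher number from compound 1 to compound 4 (0.42 log units; beyond the scatter), whereas the earlier replacements of the group on that oxygen stayed within the scatter. The appended group therefore can move the read-out towards weaker inhibition, and 1-(4-fluorophenyl)-1H-1,2,3-triazol-4-yl is the only group shown that does so.

The compounds shown leave open whether the step belongs to the triazole ring or to the 4-fluorophenyl group on it, which a plain phenyl on the same ring would separate. Also open, on these data alone, is whether a carboxylic acid on the same chain carbon would stay level with compound 1 or also move the read-out.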